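Swapping the piperazine tail for methoxy

This account rests on a few compounds, and the source may have more. Where it says the series, first, only, none or still open, it means among the compounds named here.

Measured compounds:
- Compound 1, `CN1CCN(Cc2ccc(NC(=O)Nc3ccc4ncnc(Nc5ccc(F)c(F)c5)c4c3)cc2)CC1`. In a functional assay on A-431 cells (Homo sapiens) for antiproliferative activity, read by MTT assay, with a stated time of 72 h (on this read-out higher numbers stand for weaker inhibition and lower numbers for stronger inhibition), compound 1 reaches only the limit > 10000 nM.
- Compound 2, `CN1CCN(Cc2ccc(NC(=O)Nc3ccc4ncnc(Nc5cccc(C(F)(F)F)c5)c4c3)cc2)CC1`. In this assay compound 2 gives 2410 nM.
- Compound 3, `COC(=O)c1cccc(Nc2ncnc3ccc(NC(=O)Nc4ccc(CN5CCN(C)CC5)cc4)cc23)c1`. In this assay compound 3 gives 5630 nM.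

Compound 2 holds the lowest of the two numbers actually measured. The next value lies above it: a 2.3-fold higher number from compound 2 to compound 3 (0.37 log units; beyond the scatter). Compound 1 contributes no number, only a limit (the limit of > 10000 nM in this assay, at which 1 of the 3 values shown sits).

Compound 4, `COc1ccc(NC(=O)Nc2ccc3ncnc(Nc4cccc(C(F)(F)F)c4)c3c2)cc1`, differs from compound 2 in one place: methoxy in place of (4-methylpiperazin-1-yl)methyl on an aromatic carbon. The measured steps all concern the other end of the shared core, where the group on the nitrogen of the aromatic ring is exchanged: an at least 4.1-fold lower number from compound 1 to compound 2 (0.61 log units; beyond the scatter) and an at least 1.7-fold lower number from compound 1 to compound 3 (0.24 log units; that floor lies within the scatter). Among the measured compounds shown here, neither of them, nor the step between compound 2 and compound 3, alters the tail that is replaced here, so no measured step bears directly on this change. As far as these compounds go, with nothing to point in either direction, the expectation is a step that stays within the scatter, a 1.2-fold higher number from compound 2 to compound 4 (0.10 log units; within the scatter), while allowing a wide range given that the change is untested. Compound 4 is therefore estimated at 3000 nM, between 800 nM and 12000 nM.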

Compound 4, half-maximal inhibitory concentration: 4950 nM
Compound 4: the middle estimate sits 1.7-fold (0.22 log units) below what was measured; the range from low to high includes it.
By their numbers in this assay, from the lowest: compound 2; then compounds 4 and 3 (each within the scatter of the next). At a limit, above all of these: compound 1.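

Among the compounds shown here, the earlier steps all exchanged the group on the nitrogen at the other end of the shared core, so this is the first reading of the tail, which sits on an aromatic carbon of a six-membered aromatic ring of carbon only, para to a large group. In this assay, methoxy in place of (4-methylpiperazin-1-yl)methyl gives a 2.1-fold higher number from compound 2 to compound 4 (0.31 log units; beyond the scatter) and so shows that this position does respond to an exchange, though only modestly. The six-membered non-aromatic ring is also not needed for a measured number on this core, since compound 4, with no ring in that group, still gives 4950 nM and not a limit.

Nothing measured among these compounds accounts for the size of this step. As far as these compounds go, it remains open how a simple amine, a carboxylic acid or a longer chain ending in the same 4-methylpiperazine would behave at this position, and whether methoxy would give a similar step with 3,4-difluorophenyl or 3-(methoxycarbonyl)phenyl on the nitrogen at the other end.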